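The compounds below may be only part of what the source reports. "The series", "measured", "known", "first", "only" and "open" are said of these compounds alone.

Compound 1 `CCC1=C(O)c2c(oc(-c3ccccc3)cc2=O)C(CC)(CC)C1=O`: > 236 uM
Compound 2 `CCC1=C(O)c2c(oc(-c3ccccc3C)cc2=O)C(CC)(CC)C1=O`: 40.9 uM

In a functional assay on KB cells (Homo sapiens) for antiproliferative activity, read by sulforhodamine B assay, with a stated time of 3 days (a higher number here means that more compound is needed for the effect, a lower number that less compound is needed), compound 1 stands at a limit of the assay, > 236 uM, and not at a number. For the measured compounds named here, compound 2 gives the only true number so far, 40.9 uM.

Compound 3 `CCC1=C(O)c2c(oc(-c3ccccc3C(F)(F)F)cc2=O)C(CC)(CC)C1=O` has trifluoromethyl in place of the methyl of compound 2, on an aromatic carbon of a six-membered aromatic ring of carbon only, ortho to a large group: trifluoromethyl in place of methyl on an aromatic carbon.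

Going by the values given here, one measured step bears on this change, methyl in place of hydrogen on an aromatic carbon, which gave an at least 5.7-fold lower number from compound 1 to compound 2 (0.76 log units; beyond the scatter). Among the compounds with values here, no measured compound yet carries trifluoromethyl. Compound 3 keeps a group on the carbon that changed in an at least 5.7-fold lower number from compound 1 to compound 2 (0.76 log units; beyond the scatter), so no step beyond the scatter is expected in this assay. The expected step is a 1.2-fold lower number from compound 2 to compound 3 (0.07 log units; within the scatter). The estimate for compound 3 is 35 uM, with an expected range from 10 uM to 120 uM.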

Compound 3, concentration for half-maximal effect: 45.6 uM
The estimate for compound 3 lay 1.3-fold (0.11 log units) below the measured number, and the stated range covers the measured number.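

In this assay, the methyl on this aromatic carbon, ortho to a large group, can give way to trifluoromethyl with no real change, a 1.1-fold higher number from compound 2 to compound 3 (0.05 log units; within the scatter). Measured against hydrogen, trifluoromethyl gives an at least 5.1-fold lower number from compound 1 to compound 3 (0.71 log units; beyond the scatter), so the lower number seen with methyl is not unique to methyl: compound 2 and compound 3 both follow this pattern, and neither of the compounds shown goes against it. The size of this gain over hydrogen can only be given as a bound, because compound 1 stands at a limit of the assay and not at a number: the limit of > 236 uM in this assay, at which 1 of the 3 values shown sits.

On these data alone, how large the gain over hydrogen really is remains open. Also open, as far as these compounds go, is whether a group of another kind on this carbon, such as an amine, a carboxylic acid or a longer chain, would keep the number where compound 2 and compound 3 stand.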